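The compounds below may be only part of what the source reports. "The series", "measured", "known", "first", "only" and "open" are said of these compounds alone.

Three compounds share one core and differ only in the group carried on the amine nitrogen joined to the saturated ring. Compound 1 `O=S(=O)(NCC1CCN(CCCc2c[nH]c3ccc(-n4cnnc4)cc23)CC1)c1ccccc1` gives 12 nM in an assay on CHO cells for agonist activity at 5-hydroxytryptamine receptor 1D (Homo sapiens), read by GTPgammaS binding; a lower number here means that less compound is needed, a higher number that more compound is needed for the effect. Compound 2 `O[C@@H]1Cc2ccccc2[C@H]1NC1CCN(CCCc2c[nH]c3ccc(-n4cnnc4)cc23)CC1` gives 13 nM, and compound 3 `COC[C@H](NC1CCN(CCCc2c[nH]c3ccc(-n4cnnc4)cc23)CC1)c1ccccc1` gives 0.9 nM. Compound 2 thus shows the highest number of the three, but a 1.1-fold higher number from compound 1 to compound 2 (0.03 log units; within the scatter) lies within the scatter, so no order between compound 2 and compound 1 can be claimed; by contrast a 14-fold lower number from compound 2 to compound 3 (1.16 log units; beyond the scatter) is a large step beyond the scatter.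

Compound 4 `CC(CO)(NC1CCN(CCCc2c[nH]c3ccc(-n4cnnc4)cc23)CC1)c1ccccc1` has not yet been measured. Its difference from compound 2 is 1-(hydroxymethyl)-1-phenylethyl in place of 2-hydroxy-2,3-dihydro-1H-inden-1-yl on an amine nitrogen. For the measured compounds named here, the one measured step that bears on this change is a 14-fold lower number from compound 2 to compound 3 (1.16 log units; beyond the scatter), where the same group left and an open-chain group carrying a phenyl ring and a single oxygen entered. Going by the values given here, the group entering in compound 4 also carries a phenyl ring and a single oxygen, though as a hydroxymethyl and with an extra methyl on the carbon bound to the nitrogen, for which no measured step exists. A downward step is therefore expected, likely smaller than that seen for compound 3: a 4.3-fold lower number from compound 2 to compound 4 (0.64 log units; beyond the scatter). Compound 4 is estimated at 3 nM, within a range from 0.8 nM to 12 nM.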

Compound 4, half-maximal effective concentration: 3.4 nM
Estimate against measurement, compound 4: 1.1-fold (0.05 log units) below, and the stated range covers the measured number.
By their numbers in this assay, from the lowest: compound 3; then compound 4; then compounds 1 and 2 (each within the scatter of the next).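

In this assay, the step of a 3.8-fold lower number from compound 2 to compound 4 (0.58 log units; beyond the scatter) shows that compound 3 is not a lone case: at this amine nitrogen, a second group without the five-membered ring, and with the same count of heavy atoms as 2-hydroxy-2,3-dihydro-1H-inden-1-yl, also gives a lower number. The two groups lacking that ring are not interchangeable, however, since a 3.8-fold higher number from compound 3 to compound 4 (0.58 log units; beyond the scatter) takes back part of the gain, while a 3.5-fold lower number from compound 1 to compound 4 (0.55 log units; beyond the scatter) shows that the 1-(hydroxymethyl)-1-phenylethyl group still needs less compound than the ((phenylsulfonyl)amino)methyl group of the first compound. No measurement is available that would explain any of these steps.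

Compound 3 and compound 4 differ both in how the oxygen is carried, as a methoxy or as a hydroxymethyl, and in the arrangement of the carbons around it, so the share of each difference in their step remains unresolved. Also open, as far as these compounds go, is how the series would respond if a dimethylamino group or a carboxylic acid took the place of the hydroxyl in compound 4.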